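A few compounds are considered here, and "the series" means these few. Any claim that something is new, unique, unknown or untested is made for them only; others in the source may bear on it.

Of the compounds shown here, three have been measured in an assay on isolated protein for inhibition of Trypsin II (Bos taurus); a lower number here means a stronger inhibitor, a higher number a weaker inhibitor. Compound 1 `C[n+]1ccc(-c2ccc(S(=O)(=O)N[C@H]3CCN(Cc4cccc(C(=N)N)c4)C3=O)cc2)cc1` gives only a limit there, > 2900 nM. Compound 2 `Cn1ccnc1-c1ccc(S(=O)(=O)N[C@H]2CCN(Cc3cccc(C(=N)N)c3)C2=O)cc1` likewise gives a limit, > 2900 nM. The step that the two limits leave unreadable from compound 1 to compound 2 therefore has no readable size. Compound 3 `N=C(N)c1cccc(CN2CC[C@H](NS(=O)(=O)c3ccc(-c4ccccn4)s3)C2=O)c1` also gives only a limit in this assay, > 2100 nM. The values fall at the limit of > 2900 nM in this assay, at which 2 of the 3 values shown sit, and at the limit of > 2100 nM in this assay, at which 1 of the 3 values shown sits, so compound 3 stands with the other two, and no ranking among them can be made.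

Compound 4 `COc1nccc(-c2ccc(S(=O)(=O)N[C@H]3CCN(Cc4cccc(C(=N)N)c4)C3=O)s2)n1` carries 2-methoxypyrimidin-4-yl in place of pyridin-2-yl on an aromatic carbon. Among the compounds with values here, no measured step on this core has a readable size, and no other pair of measured compounds differs in one place, so nothing measured bears directly on this change. What is expected of compound 4 in this assay rests on compound 3 alone. Compound 4 is expected to remain close to the limit, with a step that the limit leaves unreadable from compound 3 to compound 4 of no size beyond the scatter. The estimate for compound 4 is 3500 nM, within a range from 1000 nM to 12000 nM.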

Compound 4, inhibition constant: > 2900 nM
Compound 4: only a limit was reported; the forecaster's own chance of this, stated with the estimate: 70%; the middle value is on the limit's open side.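

In this assay compound 4 gives > 2900 nM as a limit only. Compound 3 also gives only a limit, so the step from compound 3 to compound 4 cannot be read. The compounds shown leave open how strong each inhibitor actually is in this assay and whether 2-methoxypyrimidin-4-yl in place of pyridin-2-yl changes that at all.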